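Branched Hydroxyalkyl Swap on a Shared Triazole Series

The source may hold more compounds than are shown below. What is called first, only, known or untested is meant among the compounds shown, and "the series" means these compounds.

Compound 1, `OCc1cn(CCNc2nonc2/C(=N/O)Nc2ccc(F)c(Br)c2)nn1`: 794 nM
Compound 2, `CC(C)(C)c1cn(CCNc2nonc2/C(=N/O)Nc2ccc(F)c(Br)c2)nn1`: 1870 nM
Compound 3, `OCCCCc1cn(CCNc2nonc2/C(=N/O)Nc2ccc(F)c(Br)c2)nn1`: 1080 nM

Three compounds built on the same core were tested in an assay on isolated protein for inhibition of Indoleamine 2,3-dioxygenase 2 (Homo sapiens); on this read-out higher numbers stand for weaker inhibition and lower numbers for stronger inhibition. Compound 3 sits second highest of the three numbers. Its nearest neighbour is compound 1, with a 1.4-fold higher number from compound 1 to compound 3 (0.13 log units; within the scatter), a gap within the scatter. Against compound 2 the picture is a 1.7-fold lower number from compound 2 to compound 3 (0.24 log units; within the scatter), again within the scatter. Within the data shown here, the only step beyond the scatter in this set is a 2.4-fold higher number from compound 1 to compound 2 (0.37 log units; beyond the scatter), where a tert-butyl group replaced a hydroxymethyl group.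

Compound 4, `CC(C)CC(C)(O)c1cn(CCNc2nonc2/C(=N/O)Nc2ccc(F)c(Br)c2)nn1`, differs from compound 3 in one place: 1-hydroxy-1,3-dimethylbutyl in place of 4-hydroxybutyl on an aromatic carbon. Among the measured compounds shown here, two measured steps bear on this. Putting the bulky tert-butyl group in place of hydroxymethyl produced a 2.4-fold higher number from compound 1 to compound 2 (0.37 log units; beyond the scatter), a modest move toward weaker inhibition. Replacing that tert-butyl with the longer 4-hydroxybutyl chain gave a 1.7-fold lower number from compound 2 to compound 3 (0.24 log units; within the scatter), within the scatter. The entering group keeps a hydroxyl, as in compound 3, but is branched and larger, more like the tert-butyl of compound 2. A small step toward higher numbers is therefore expected, near the edge of the scatter.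

Compound 4 is expected to give 1600 nM, with a likely range of 700 nM to 3600 nM. This corresponds to an expected step of a 1.5-fold higher number from compound 3 to compound 4 (0.17 log units; within the scatter).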

Compound 4, half-maximal inhibitory concentration: 689 nM
The estimate for compound 4 lay 2.3-fold (0.37 log units) above the measured number; the measured number lies below the stated range.
By their numbers in this assay, from the lowest: compounds 4, 1, 3 and 2 (each within the scatter of the next, the first and the last beyond it).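

In this assay, the larger, branched 1-hydroxy-1,3-dimethylbutyl group on this aromatic carbon lands level with both unbranched hydroxyl groups, at a 1.6-fold lower number from compound 3 to compound 4 (0.20 log units; within the scatter) and a 1.2-fold lower number from compound 1 to compound 4 (0.06 log units; within the scatter), so on these compounds a branched group at this position does not by itself mean a higher number. Among these compounds, the one new step beyond the scatter is a 2.7-fold lower number from compound 2 to compound 4 (0.43 log units; beyond the scatter), which separates two branched groups, only one of which carries a hydroxyl; this link between the hydroxyl and a lower number is only partial, as compound 3 also carries a hydroxyl yet shows a 1.7-fold lower number from compound 2 to compound 3 (0.24 log units; within the scatter), a step within the scatter. No available evidence explains why the new group behaves this way.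

On these data alone, whether the hydroxyl of compound 4 matters remains open, and a comparison with the same branched chain lacking it, 1,3-dimethylbutyl, would test that directly. As far as these compounds go, how an amine or a carboxylic acid would fare on this aromatic carbon also remains unknown.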